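Tetrazole Methyl Isomers on a Biphenyl Side Chain

This account rests on a few compounds, and the source may have more. Where it says the series, first, only, none or still open, it means among the compounds named here.

Among the measured compounds shown here, compound 1 `Cn1nnnc1-c1ccccc1-c1ccc(CN2C(=O)[C@H](NC(=O)CC(C)(C)N)CCc3ccccc32)cc1` gives 0.5 uM in a functional assay (Pituitary gland cell) with Rattus norvegicus as the target (a higher number here means that more compound is needed for the effect, a lower number that less compound is needed), the lowest of the two numbers known; compound 2 `COC(=O)c1ccccc1-c1ccc(CN2C(=O)[C@H](NC(=O)CC(C)(C)N)CCc3ccccc32)cc1` gives 2 uM, and the step of a 4.0-fold higher number from compound 1 to compound 2 (0.60 log units; beyond the scatter) is the only one measured. Compound 3 `Cn1nnc(-c2ccccc2-c2ccc(CN3C(=O)[C@H](NC(=O)CC(C)(C)N)CCc4ccccc43)cc2)n1` differs from compound 1 by 2-methyl-2H-tetrazol-5-yl in place of 1-methyl-1H-tetrazol-5-yl on an aromatic carbon. For the measured compounds named here, no measured step isolates this change; the step of a 4.0-fold higher number from compound 1 to compound 2 (0.60 log units; beyond the scatter) shows only that swapping the group at this place can move this assay modestly. He therefore expects a step of a 2.0-fold higher number from compound 1 to compound 3 (0.30 log units; within the scatter), small and of uncertain direction. Compound 3 is estimated at 1 uM, between 0.3 uM and 4 uM.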

Compound 3, concentration for half-maximal effect: 0.3 uM
Compound 3: the middle estimate sits 3.3-fold (0.52 log units) above what was measured, within the range that was stated.
By their numbers in this assay, from the lowest: compounds 3 and 1 (each within the scatter of the next); then compound 2.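

The step of a 1.7-fold lower number from compound 1 to compound 3 (0.22 log units; within the scatter) shows that at this place, ortho to a large group, the two methyl tetrazole isomers cannot be told apart in this assay on these numbers. The step of a 6.7-fold lower number from compound 2 to compound 3 (0.82 log units; beyond the scatter) shows that the gap to the methoxycarbonyl group holds for both isomers. No supporting data explain this result.

The compounds shown leave open how a carboxylic acid or a tetrazole without its methyl group on this aromatic carbon would read in this assay and whether the methyl group matters at all.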